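Notes on aryl replacement in a growth-inhibition series

This account rests on a few compounds, and the source may have more. Where it says the series, first, only, none or still open, it means among the compounds named here.

Values in a functional assay on NCI-H460 cells (Homo sapiens) for inhibition, read by sulforhodamine B assay, with a stated time of 48 h; on this read-out higher numbers stand for weaker inhibition of growth and lower numbers for stronger inhibition of growth:
compound 1 `COC(=O)c1sc2cc(-c3ccsc3)cnc2c1N`: 12400 nM
compound 2 `COC(=O)c1sc2cc(-c3cnn(C)c3)cnc2c1N`: > 150000 nM
compound 3 `COC(=O)c1sc2cc(-c3ccc(C#N)cc3)cnc2c1N`: > 75000 nM

Compound 3 gives only a limit of the assay in this assay, (the limit of > 75000 nM in this assay, at which 1 of the 3 values shown sits), so no number stands for it. Compound 2 likewise sits at a limit, (the limit of > 150000 nM in this assay, at which 1 of the 3 values shown sits). Compound 1 alone has a number. For the measured compounds named here, the only measured step, an at least 12-fold higher number from compound 1 to compound 2 (1.08 log units; beyond the scatter), concerns a different aryl change and does not bear on the change to compound 4. Compound 4 `COC(=O)c1sc2cc(-c3ccc(C(C)=O)cc3)cnc2c1N` differs from compound 3 by acetyl in place of cyano on an aromatic carbon. Going by the values given here, no measured step covers this change, so nothing beyond the scatter is expected in either direction. Compound 4 is therefore expected to stay near the limit of compound 3, estimated at 80000 nM with a range from 20000 nM to 300000 nM. The expected step is a step that the limit leaves unreadable from compound 3 to compound 4.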

Compound 4, concentration for 50% growth inhibition: > 150000 nM
Compound 4 ended at the assay's limit (the forecaster's own chance of this, stated with the estimate: 60%); middle value at least 1.8-fold (0.27 log units) away from the limit.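

For the compounds shown here, compound 3 and compound 4 both give only limits of the assay, so no step between them can be read. As far as these compounds go, whether acetyl in place of cyano changes growth inhibition at all remains open.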